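An ethoxy extension on the amino side chain

This account rests on a few compounds, and the source may have more. Where it says the series, first, only, none or still open, it means among the compounds named here.

Among the compounds with values here, compound 3 `CCNc1nc(C)c(-c2nc3ccccc3s2)c(N[C@@H]2C[C@H](CO)[C@@H](O)[C@H]2O)n1` is the only member of this small set whose tolerated concentration is resolved as a number in an ADME assay on cells (Homo sapiens) for cytotoxicity, read by polymerase chain reaction, with a stated time of 3 days; a higher number here means that more compound is tolerated, a lower number that less compound is tolerated. In this assay compound 3 gives 12000 nM. Compound 1 `Nc1nc(Cl)c(-c2cccs2)c(N[C@@H]2C[C@H](CO)[C@@H](O)[C@H]2O)n1` reaches only a limit of the assay; in this assay compound 1 gives > 25000 nM. Compound 2 `Nc1ncc(-c2nc3ccccc3s2)c(N[C@@H]2C[C@H](CO)[C@@H](O)[C@H]2O)n1` likewise stops at a limit; in this assay compound 2 gives > 25000 nM. Within the data shown here, compound 3 thus stands alone as the one resolved value, while the other two sit at the limit of > 25000 nM in this assay, at which 2 of the 3 values shown sit. Among the measured compounds shown here, no pair of measured compounds differs in a single place, so no measured step is available to guide the next change.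

Compound 4 `CCOCCNc1nc(C)c(-c2nc3ccccc3s2)c(N[C@@H]2C[C@H](CO)[C@@H](O)[C@H]2O)n1` differs from compound 3 by ethoxy in place of hydrogen on a saturated chain carbon, two bonds along the chain from a nitrogen on an aromatic ring. The amino side chain grows, and the rest of the molecule stays as it is. For the measured compounds named here, with no measured step to lean on, the change in this assay is expected to be small, either within the usual scatter or a modest move toward more compound being tolerated, and the expected step is a 1.3-fold higher number from compound 3 to compound 4 (0.10 log units; within the scatter). Compound 4 is therefore estimated at 15000 nM in this assay, with a range from 6000 nM to 30000 nM, and with a fair chance that it too returns only a limit.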

Compound 4, half-maximal cytotoxic concentration: 18000 nM
Compound 4: the middle estimate sits 1.2-fold (0.08 log units) below what was measured; measured number inside the range.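

In this assay, within the data shown here, the only step that can be read in this set is a 1.5-fold higher number from compound 3 to compound 4 (0.18 log units; within the scatter), so the two compounds cannot be told apart, and ethoxy in place of hydrogen on a saturated chain carbon, two bonds along the chain from a nitrogen on an aromatic ring, leaves the reading within the usual scatter. This position therefore accepts the swap of ethyl for 2-ethoxyethyl, with its three extra heavy atoms including one oxygen, and compound 4 still returns a resolved number rather than a limit. Compound 1 and compound 2 remain limits of the assay, not numbers: the limit of > 25000 nM in this assay, at which 2 of the 4 values shown sit.

One step at one position cannot show whether the flat reading holds for other groups on this chain, such as a terminal amine, a carboxylic acid or a longer chain of carbons, any of which might move the number beyond the scatter. It also leaves open whether the same ethoxy change would read alike on another core, and the compounds shown give no cause for the small step.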